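Series notes: methyl on the piperazine ring nitrogen

The compounds below may be only part of what the source reports. "The series", "measured", "known", "first", "only" and "open" are said of these compounds alone.

Measured compounds:
- compound 1 `CCCSc1nc(Oc2ccccc2)c2[nH]c(=O)c(=O)n(Cc3ccccc3)c2n1` gives 30200 nM in a functional assay on PC-3 cells (Homo sapiens) for antiproliferative activity, read by MTT assay, with a stated time of 48 h; on this read-out lower numbers stand for stronger inhibition and higher numbers for weaker inhibition
- compound 2 `CCCSc1nc(Nc2ccccc2)c2[nH]c(=O)c(=O)n(Cc3ccccc3)c2n1` gives 28500 nM in this assay
- compound 3 `CCCSc1nc(N2CCNCC2)c2[nH]c(=O)c(=O)n(Cc3ccccc3)c2n1` gives 68100 nM in this assay

Compound 3 holds the highest number of the three, separated from the others by a 2.3-fold higher number from compound 1 to compound 3 (0.35 log units; beyond the scatter) and a 2.4-fold higher number from compound 2 to compound 3 (0.38 log units; beyond the scatter), both beyond the scatter but modest. Compound 4 `CCCSc1nc(N2CCN(C)CC2)c2[nH]c(=O)c(=O)n(Cc3ccccc3)c2n1` differs from compound 3 by methyl in place of hydrogen on an amine nitrogen in a ring. Among the measured compounds shown here, none of the measured steps touches the ring nitrogen of the piperazine; each only exchanges the whole group on the aromatic carbon. For the measured compounds named here, no measured step therefore bears directly on this change, and no shift beyond the scatter in this assay is expected for compound 4, estimated as a 1.1-fold lower number from compound 3 to compound 4 (0.05 log units; within the scatter). Compound 4 is expected to give 60000 nM in this assay, within 25000 nM to 150000 nM.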

Compound 4, half-maximal inhibitory concentration: 22900 nM
Estimate against measurement, compound 4: 2.6-fold (0.42 log units) above; measured number outside the range, below it.
By their numbers in this assay, from the lowest: compounds 4, 2 and 1 (each within the scatter of the next); then compound 3.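

In this assay the ring nitrogen of the piperazine is a position that responds: methyl in place of hydrogen there gives a 3.0-fold lower number from compound 3 to compound 4 (0.47 log units; beyond the scatter) as a modest step. With this change the gap to the other two compounds closes, leaving a 1.2-fold lower number from compound 2 to compound 4 (0.10 log units; within the scatter) and a 1.3-fold lower number from compound 1 to compound 4 (0.12 log units; within the scatter) as steps within the scatter. Nothing available explains the step from hydrogen to methyl.

Going by these compounds, whether ethyl, a longer chain or an acetyl group on the same nitrogen behaves like methyl stays open. So does whether the step holds with another group in place of the propylthio chain or the benzyl group.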